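Benzyloxycarbonyl in place of methoxycarbonyl on compound 3

The source may report more compounds than this note shows. Statements on the series, on what has been measured and on what is new or still open speak of the compounds shown alone.

Measured in a functional assay on A2780 cells (Homo sapiens) for antiproliferative activity, read by MTT assay, with a stated time of 48 h; on this read-out higher numbers stand for weaker inhibition of growth and lower numbers for stronger inhibition of growth:
- compound 1 `COC(=O)N1N=C(c2cccc(OC)c2)CC1c1cc(OC)c(OC)c(OC)c1`: 2780 nM
- compound 2 `COc1ccc(C2=NN(C(=O)OCc3ccccc3)C(c3cc(OC)c(OC)c(OC)c3)C2)cc1`: > 10000 nM, a limit of the assay and not a number
- compound 3 `COC(=O)N1N=C(c2cccc(O)c2)CC1c1cc(OC)c(OC)c(OC)c1`: 810 nM

Compound 3 gives 810 nM, the lowest of the two actual numbers in the series. Within the data shown here, the only measured step is a 3.4-fold lower number from compound 1 to compound 3 (0.54 log units; beyond the scatter).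

Compound 4 `COc1cc(C2CC(c3cccc(O)c3)=NN2C(=O)OCc2ccccc2)cc(OC)c1OC` differs from compound 3 by one change: phenyl in place of hydrogen on a saturated chain carbon bound to an oxygen next to a carbonyl group, which also reads as methoxycarbonyl to benzyloxycarbonyl. The measured step lies elsewhere on the molecule and does not size this change. Among the measured compounds shown here, compound 2 is the only measured compound carrying benzyloxycarbonyl, and the closest evidence is the limit of > 10000 nM in this assay, at which 1 of the 3 values shown sits. For the measured compounds named here, compound 2 also differs from compound 1 in more than this group, so no clean step exists for the change. A higher number is nevertheless expected in this assay, with wide uncertainty. The expected step is a 3.7-fold higher number from compound 3 to compound 4 (0.57 log units; beyond the scatter). The estimate for compound 4 is 3000 nM, with an expected range from 800 nM to 10000 nM.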

Compound 4, concentration for 50% growth inhibition: > 10000 nM
Compound 4 ended at the assay's limit; the forecaster's own chance of this, stated with the estimate: 25%; middle value at least 3.3-fold (0.52 log units) from the limit.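

In this assay the change from methoxycarbonyl to benzyloxycarbonyl now has a step between two compounds that differ in one place only: an at least 12-fold higher number from compound 3 to compound 4 (1.09 log units; beyond the scatter) is large, and the value of compound 4 is a limit of the assay and not a number, so the step gives only a lower bound on the size. Compound 4 keeps the 3-hydroxyphenyl group of compound 3, so that group does not hold the activity once phenyl enters at this place. The step from compound 2 to compound 4 cannot be read, and both compounds carrying benzyloxycarbonyl sit at the same limit: the limit of > 10000 nM in this assay, at which 2 of the 4 values shown sit.

Open, from the compounds shown here alone, is whether a longer chain in place of the methyl, without an aromatic ring, keeps the activity of compound 3. Also open, going by these compounds, is whether an amine on the added phenyl ring changes the outcome.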